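The source may hold more compounds than are shown below. What is called first, only, known or untested is meant among the compounds shown, and "the series" means these compounds.

Working notes on the step from compound 2 to compound 3. In a physicochemical assay for solubility, at pH 7.4 (on this read-out higher numbers stand for higher solubility and lower numbers for lower solubility), compound 2 `OCCCc1nc(Nc2ccc(C(F)(F)F)cc2)c2ccc(-c3ncccc3C(F)(F)F)cc2n1` gives 0.06 ug/mL, the only true number shown so far. Compound 1 `O=P(O)(O)OCc1nc(Nc2ccc(C(F)(F)F)cc2)c2ccc(-c3ncccc3C(F)(F)F)cc2n1` reads > 138 ug/mL, which is a limit of the assay and not a number. The evidence at hand therefore holds only (the limit of > 138 ug/mL in this assay, at which 1 of the 2 values shown sits).

Compound 3 `CNCc1nc(Nc2ccc(C(F)(F)F)cc2)c2ccc(-c3ncccc3C(F)(F)F)cc2n1` differs from compound 2 by one change: methylamino in place of 2-hydroxyethyl on a saturated chain carbon bound to an aromatic carbon. In words, methylamino stands in place of 2-hydroxyethyl on a saturated chain carbon bound to an aromatic carbon.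

Within the data shown here, one measured step bears on this place: an at least 2300-fold lower number from compound 1 to compound 2 (3.36 log units; beyond the scatter). It is large and beyond the scatter, but it is bounded by a limit on one side and involves a different group, so it shows only that this place can move the read-out widely. Starting from compound 2 at 0.06 ug/mL, a moderate rise in this assay is expected, far smaller than that measured step. The expected step is an 8.3-fold higher number from compound 2 to compound 3 (0.92 log units; beyond the scatter). For compound 3 the estimated value is 0.5 ug/mL, with an expected range of 0.08 ug/mL to 5 ug/mL.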

Compound 3, solubility: 10 ug/mL
For compound 3 the middle estimate is 20-fold (1.30 log units) below the measured one; the measured number lies above the stated range.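

The step to methylamino shows that this place can move the read-out widely without a phosphorus-bearing group: in this assay, methylamino in place of 2-hydroxyethyl on a saturated chain carbon bound to an aromatic carbon gives a 170-fold higher number from compound 2 to compound 3 (2.22 log units; beyond the scatter). This large step comes with no difference in the printed counts of hydrogen-bond donors, hydrogen-bond acceptors or net charge, so those counts do not separate compound 2 from compound 3. The uncharged amine-bearing side chain still does not reach the group of compound 1, with an at least 13-fold lower number from compound 1 to compound 3 (1.13 log units; beyond the scatter), and the value of compound 1 remains a limit of the assay and not a number, so this step gives only a lower bound on the gap.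

Cut one bond further out, the same difference reads 3-hydroxypropyl to (methylamino)methyl, so the exchange of oxygen for nitrogen and the shortening of the chain travel together in this step. A 3-aminopropyl chain would part the two, while a dimethylamino group or a carboxylic acid at this place would show how far the read-out depends on the amine hydrogen or on the amine at all.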